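A few compounds are considered here, and "the series" means these few. Any claim that something is new, unique, unknown or untested is made for them only; others in the source may bear on it.

Of the compounds shown here, three built on a shared core have been measured in a functional assay on A549 cells (Homo sapiens) for antiproliferative activity, read by sulforhodamine B assay, with a stated time of 48 h; on this read-out higher numbers stand for weaker inhibition of growth and lower numbers for stronger inhibition of growth. Compound 3 (`OCCCNc1nc(Nc2ccc(F)cc2)nc2ccccc12`) gives 19300 nM and compound 1 (`COc1ccc(Nc2nc(NCCCO)c3ccccc3n2)cc1`) gives 15200 nM, two values within the scatter of each other. Compound 2 (`CCCNc1nc(Nc2ccc(OC)cc2)nc2ccccc12`) gives 3530 nM, a number clearly lower than both, so compound 3 shares the upper end of this small range with compound 1.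

Compound 4 (`CCCNc1nc(Nc2ccc(F)cc2)nc2ccccc12`) has not been measured. It differs from compound 3 in one place: hydrogen in place of hydroxy on a saturated chain carbon, three bonds along the chain from a nitrogen on an aromatic ring, which turns 3-hydroxypropyl into propyl. The same change has been measured once before, on the methoxy side of the series, as a 4.3-fold lower number from compound 1 to compound 2 (0.63 log units; beyond the scatter). That modest step lies beyond the scatter. The swap of methoxy for fluoro, seen as a 1.3-fold higher number from compound 1 to compound 3 (0.10 log units; within the scatter), stays within the scatter, so the earlier step can reasonably be carried over to the fluoro compounds. This rests on a single pair, however, and the change may not repeat exactly.

A step of similar size towards a lower number is therefore expected, and the estimated step is a 4.3-fold lower number from compound 3 to compound 4 (0.63 log units; beyond the scatter). For compound 4 the expected value is 4500 nM, with an estimated range from 2000 nM to 10000 nM.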

Compound 4, concentration for 50% growth inhibition: 4300 nM
Beside the measured number, compound 4's estimate is 1.0-fold (0.02 log units) above it; measured number inside the range.
By their numbers in this assay, from the lowest: compounds 2 and 4 (each within the scatter of the next); then compounds 1 and 3 (each within the scatter of the next).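

Replacing hydroxy with hydrogen on the chain is no longer a single observation: on the fluoro side it gives a 4.5-fold lower number from compound 3 to compound 4 (0.65 log units; beyond the scatter), and the two steps match closely: the same change on two cores in this assay, a 4.3-fold lower number (0.63 log units; beyond the scatter) from compound 1 to compound 2 and a 4.5-fold lower number (0.65 log units; beyond the scatter) from compound 3 to compound 4, 1.0-fold (0.02 log units) apart, within the scatter of two such steps

The swap of methoxy for fluoro can now also be read on the propyl compounds, where it gives a 1.2-fold higher number from compound 2 to compound 4 (0.09 log units; within the scatter), and it behaves just as it did on the 3-hydroxypropyl compounds: the same change on two cores in this assay, a 1.3-fold higher number (0.10 log units; within the scatter) from compound 1 to compound 3 and a 1.2-fold higher number (0.09 log units; within the scatter) from compound 2 to compound 4, 1.0-fold (0.02 log units) apart, within the scatter of two such steps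

Across these four compounds, the two changes therefore appear independent of each other: going from 3-hydroxypropyl to propyl lowers the number whichever of the two aromatic substituents is present, while methoxy and fluoro stay within the scatter of each other whichever of the two chains is present.

The compounds shown cannot tell what an amine or a carboxylic acid in place of the hydroxy would do, or how a longer chain than propyl would compare. They also leave open why losing the hydroxy lowers the number, and whether a chloro group in place of fluoro would leave the number as unchanged as the swap of methoxy for fluoro does.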